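This account rests on a few compounds, and the source may have more. Where it says the series, first, only, none or still open, it means among the compounds named here.

Measured so far:
- Compound 1 `C=C(c1ccc(Cl)c(Cl)c1)C1COC(C)(C)OO1`: > 100000 nM (a limit, not a number)
- Compound 2 `C=C(c1ccc(Cl)c(Cl)c1Cl)C1COC(C)(C)OO1`: 52100 nM

These results come from a functional assay on A549 cells (Homo sapiens) for inhibition, read by MTT assay, with a stated time of 72 h; on this read-out lower numbers stand for stronger inhibition and higher numbers for weaker inhibition. For the measured compounds named here, compound 2 holds the only actual number in this assay. Compound 1 sits at a limit: the limit of > 100000 nM in this assay, at which 1 of the 2 values shown sits.

Compound 3 `C=C(c1ccc(Cl)cc1Cl)C1COC(C)(C)OO1` has not yet been measured. Its difference from compound 2 is hydrogen in place of chloro on an aromatic carbon; in words, hydrogen in place of chloro on an aromatic carbon.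

Going by the values given here, only one measured step bears on this change. It is the same kind of exchange in the opposite sense, on a different carbon of the ring: an at least 1.9-fold lower number from compound 1 to compound 2 (0.28 log units; that floor lies within the scatter). That step is known only as a floor and lies within the scatter, so it offers weak guidance. Going by an at least 1.9-fold lower number from compound 1 to compound 2 (0.28 log units; that floor lies within the scatter), removing a chloro from compound 2 is expected to shift the number slightly upward, with no clear move beyond the scatter. The expected change is a 1.5-fold higher number from compound 2 to compound 3 (0.19 log units; within the scatter). For compound 3 the estimated value is 80000 nM, with an expected range of 35000 nM to 180000 nM.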

Compound 3, half-maximal inhibitory concentration: 92600 nM
Estimate against measurement, compound 3: 1.2-fold (0.06 log units) below; measured number inside the range.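

In this assay, hydrogen in place of the chloro that sits ortho to two chloro groups and meta to a large group gives a 1.8-fold higher number from compound 2 to compound 3 (0.25 log units; within the scatter). For the compounds shown here, this is the first step with a number at both ends, and it shows that this exchange, at this carbon, does not move the read-out beyond the usual scatter. Compound 1 remains a limit and not a number, so the earlier chloro exchange on a different ring carbon still gives only a floor, and the true size of that step stays unknown: the limit of > 100000 nM in this assay, at which 1 of the 3 values shown sits.

The compounds shown carry only chloro or hydrogen on the aromatic ring, so it stays open how a fluoro, a methoxy or an amine at this carbon would read in this assay. It is also open whether a longer chain on the shared core would bring any compound's number beyond the scatter of the values seen here, since the steps shown so far all remain within it.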